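Dimethylamino in Place of Methyl: Compound 3 Awaited

The compounds below may be only part of what the source reports. "The series", "measured", "known", "first", "only" and "open" are said of these compounds alone.

Measured so far:
compound 1, `CC(=O)OC[C@H]1O[C@@H](n2cc(CN3C(=O)/C(=C/c4ccc(C)cc4)c4ccccc43)nn2)[C@H](OC(C)=O)[C@@H](OC(C)=O)[C@@H]1OC(C)=O`, 9300 nM
compound 2, `CC(=O)OC[C@H]1O[C@@H](n2cc(CN3C(=O)/C(=C\c4ccc(C)cc4)c4ccccc43)nn2)[C@H](OC(C)=O)[C@@H](OC(C)=O)[C@@H]1OC(C)=O`, 9400 nM

In a functional assay on DU-145 cells (Homo sapiens) for cytotoxicity, read by sulforhodamine B assay, with a stated time of 48 h (on this read-out higher numbers stand for weaker inhibition and lower numbers for stronger inhibition), compound 1 gives 9300 nM and compound 2 gives 9400 nM; the step of a 1.0-fold higher number from compound 1 to compound 2 (0.00 log units; within the scatter) is within the scatter, so the two cannot be told apart on these numbers. That step is the only one measured, and it rests on (the fact that compounds 1 and 2 differ only in the configuration as drawn), a change of configuration alone; it says nothing about the substituent on the outer aromatic ring.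

Compound 3, `CC(=O)OC[C@H]1O[C@@H](n2cc(CN3C(=O)/C(=C/c4ccc(N(C)C)cc4)c4ccccc43)nn2)[C@H](OC(C)=O)[C@@H](OC(C)=O)[C@@H]1OC(C)=O`, differs from compound 1 by dimethylamino in place of methyl on an aromatic carbon. For the measured compounds named here, no measured step bears on this change, so there is no ground in the numbers for a shift in either direction, and the expectation for this assay is a step no larger than the scatter. Compound 3 is therefore expected to give about 8000 nM, within 2500 nM to 25000 nM, an expected step of a 1.2-fold lower number from compound 1 to compound 3 (0.07 log units; within the scatter).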

Compound 3, half-maximal inhibitory concentration: 11200 nM
Estimate against measurement, compound 3: 1.4-fold (0.15 log units) below; the measured number falls inside the stated range.
By their numbers in this assay, from the lowest: compounds 1, 2 and 3 (each within the scatter of the next).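

In this assay, dimethylamino in place of methyl on an aromatic carbon, para to a large group, comes with a 1.2-fold higher number from compound 1 to compound 3 (0.08 log units; within the scatter). For the compounds shown here, this is the first reading of any change of substituent at this position, since compounds 1 and 2 differ only in configuration, and it shows that this exchange, which adds heavy atoms and a nitrogen, cannot be told apart from compound 1 on these numbers. Nothing available gives a cause for this result.

Still open, from the compounds shown here alone, is whether a carboxylic acid, a primary amine or a longer chain at this position would give a step beyond the scatter. Also open, going by these compounds, is whether dimethylamino would read the same with the double bond drawn Z, and whether changes elsewhere on the shared core would matter more.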